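This account rests on a few compounds, and the source may have more. Where it says the series, first, only, none or still open, it means among the compounds named here.

Measured so far:
- compound 1 `N#C[Se]c1ccc(NC(=O)Oc2ccc(F)cc2)cc1` — 8800 nM
- compound 2 `CCCCOC(=O)Nc1ccc([Se][Se]c2ccc(NC(=O)OCCCC)cc2)cc1` — 27600 nM

In a functional assay on HT-29 cells (Homo sapiens) for cytotoxicity, read by MTT assay, with a stated time of 72 h (on this read-out higher numbers stand for weaker inhibition of growth and lower numbers for stronger inhibition of growth), compound 1 gives 8800 nM, the lower of the two numbers; compound 2 gives 27600 nM, a gap that lies beyond the scatter. For the measured compounds named here, no pair that differs in one place has been measured, so no step size is yet known for this series.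

Compound 3 `N#C[Se]c1ccc(NC(=O)Oc2ccccc2)cc1` differs from compound 1 by hydrogen in place of fluoro on an aromatic carbon, with a hydrogen entering at the position the fluoro leaves. Removing one fluorine at this position on an otherwise unchanged structure is expected to give a step of a 1.3-fold higher number from compound 1 to compound 3 (0.10 log units; within the scatter) that is small, of either direction, and not beyond the scatter. For compound 3 the estimate is 11000 nM, in the range 4000 nM to 30000 nM.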

Compound 3, concentration for 50% growth inhibition in the HT-29 assay: 11700 nM
Estimate against measurement, compound 3: 1.1-fold (0.03 log units) below; the range from low to high includes it.
By their numbers in the HT-29 assay, from the lowest: compounds 1 and 3 (each within the scatter of the next); then compound 2.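

In the HT-29 assay the change from fluoro to hydrogen on the aromatic carbon para to a large group gives a 1.3-fold higher number from compound 1 to compound 3 (0.12 log units; within the scatter) and so shows that this fluorine can go without a shift beyond the scatter. In a physicochemical assay, with a stated time of 6 min, tested at 0.1 mg/mL (on this read-out lower numbers stand for less inhibition and higher numbers for more inhibition at the one concentration tested (going by the name of the read-out)), compound 1 gives > 25% as a limit of the assay and not a number. In the physicochemical assay compound 3 gives > 25% as a limit too, so the step there cannot be read: the limit of > 25% in the physicochemical assay, at which 2 of the 2 values shown sit.

Open, on these data alone, is whether an amine or a carboxylic acid at this position would move the number in the HT-29 assay beyond the scatter.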